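Notes on the ring-nitrogen substituent step to compound 4

The source may report more compounds than this note shows. Statements on the series, on what has been measured and on what is new or still open speak of the compounds shown alone.

Measured in a functional assay on Huh-7 cells (Homo sapiens) for antiproliferative activity, read by sulforhodamine B assay, with a stated time of 72 h; a lower number here means a stronger inhibitor, a higher number a weaker inhibitor:
compound 1 `Cc1ccccc1COc1ccc(-c2cc(CN3CCN(Cc4ccc(C(F)(F)F)cc4)CC3)no2)cc1`: 1200 nM
compound 2 `Fc1cccc(COc2ccc(-c3cc(CN4CCN(Cc5ccc(C(F)(F)F)cc5)CC4)no3)cc2)c1`: 1300 nM
compound 3 `N#Cc1cccc(COc2ccc(-c3cc(CN4CCN(c5ccc(C(F)(F)F)cn5)CC4)no3)cc2)c1`: 1700 nM

All three numbers lie within the scatter of one another; compound 3 sits within the scatter of both compound 2 and compound 1. Among the compounds with values here, the one measured step, a 1.1-fold higher number from compound 1 to compound 2 (0.03 log units; within the scatter), concerns the group on the saturated chain carbon bound to the oxygen and is within the scatter.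

Compound 4 `CC(C)(C)OC(=O)N1CCN(Cc2cc(-c3ccc(OCc4cccc(C#N)c4)cc3)on2)CC1` differs from compound 3 by tert-butoxycarbonyl in place of 5-(trifluoromethyl)pyridin-2-yl on an amine nitrogen in a ring. Within the data shown here, no measured step touches this ring nitrogen, so nothing here tells the size or direction of the move in this assay. The estimate is therefore set wide around a modestly weaker value: for compound 4 the expected result is 4000 nM, range 1200 nM to 15000 nM, which would mean an expected step of a 2.4-fold higher number from compound 3 to compound 4 (0.37 log units; beyond the scatter).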

Compound 4, half-maximal inhibitory concentration: 6100 nM
The estimate for compound 4 lay 1.5-fold (0.18 log units) below the measured number; low and high end bracket the measured number.
By their numbers in this assay, from the lowest: compounds 1, 2 and 3 (each within the scatter of the next); then compound 4.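

Within the data shown here, the ring nitrogen responds to its substituent: in this assay, tert-butoxycarbonyl in place of 5-(trifluoromethyl)pyridin-2-yl gives a 3.6-fold higher number from compound 3 to compound 4 (0.55 log units; beyond the scatter), the first step in this set beyond the scatter. The earlier step, on the saturated chain carbon bound to the oxygen, stayed within the scatter. Nothing at hand bears on what underlies this step.

Open, from the compounds shown here alone, is whether the change in number follows the loss of the aromatic ring or the arrival of tert-butoxycarbonyl. A plain phenyl ring, an acetyl group or the free amine on this nitrogen could separate the two.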